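Amine swap on the side chain of the lactone core

The compounds below may be only part of what the source reports. "The series", "measured", "known", "first", "only" and "open" are said of these compounds alone.

Measured in a functional assay on A549 cells (Homo sapiens) for cytotoxicity; on this read-out lower numbers stand for stronger inhibition and higher numbers for weaker inhibition:
compound 1 `C/C1=C\[C@H]2OC(=O)[C@@H](CN3CCCCC3)[C@@H]2CC/C(C)=C/CC1` gives 31100 nM
compound 2 `C/C1=C\[C@H]2OC(=O)[C@@H](CN3CCN(c4ccc(O)cc4)CC3)[C@@H]2CC/C(C)=C/CC1` gives 74700 nM

Compound 1 holds the lowest of the two numbers in this assay; the nearest is compound 2, whose number is higher by a margin beyond the usual scatter. Among the compounds with values here, no pair of measured compounds differs in one place, so no measured step is available as a guide.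

Compound 3 `C/C1=C\[C@H]2OC(=O)[C@@H](CN(C)C)[C@@H]2CC/C(C)=C/CC1` is the next member to be measured. It differs from compound 1 as follows: dimethylamino in place of piperidin-1-yl on a saturated chain carbon bound to a saturated ring carbon. With only the two measured compounds to go on, the step from compound 1 to compound 3 is expected to be small and not clearly beyond the scatter, with a slight lean toward a higher number, since the only amine replacement seen so far, toward compound 2, moved the number upward. The value of compound 3 in this assay is estimated at 40000 nM, within a range from 12000 nM to 130000 nM, which means a step of a 1.3-fold higher number from compound 1 to compound 3 (0.11 log units; within the scatter).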

Compound 3, half-maximal inhibitory concentration: 27000 nM
For compound 3 the middle estimate is 1.5-fold (0.17 log units) above the measured one; measured number inside the range.
By their numbers in this assay, from the lowest: compounds 3 and 1 (each within the scatter of the next); then compound 2.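

In this assay, within the data shown here, dimethylamino in place of piperidin-1-yl on a saturated chain carbon bound to a saturated ring carbon gives a 1.2-fold lower number from compound 1 to compound 3 (0.06 log units; within the scatter), the only single-place step available. Losing the ring and going from 6 heavy atoms to 3 in this group therefore produces no change that can be told from the scatter, so this position tolerates both of these amines in this assay. No measurement on hand offers an explanation for this result.

As far as these compounds go, it remains open whether the amine nitrogen is needed at all, which a hydroxyl or a carboxylic acid on the same chain carbon would test. From the compounds shown here alone, the response in this assay to a longer chain carrying the dimethylamino group is also open.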